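The source may report more compounds than this note shows. Statements on the series, on what has been measured and on what is new or still open speak of the compounds shown alone.

Measured compounds in this series:

Compound 1 `CC[N+]1(CCCCCCCOc2ccc(-n3cc(C(=O)Nc4cc(F)cc(F)c4)c(=O)c4ccc(N(C)C)nc43)cc2C)CCCCC1` — 19.7%
Compound 2 `CC[N+]1(CCCCCCCOc2ccc(-n3cc(C(=O)Nc4cc(F)cc(F)c4)c(=O)c4ccc(N(C)C)nc43)cc2Cl)CCCCC1` — 14.3%
Compound 3 `Cc1cc(OCCCCCCC[N+]2(C)CCN(C)CC2)ccc1-n1cc(C(=O)Nc2cc(F)cc(F)c2)c(=O)c2ccc(N(C)C)nc21` — "not active" (no number reported)

All three were tested in an assay on LX2 cells for inhibition of COL1A1 promoter (Homo sapiens), read by a luciferase reporter, with a stated time of 24 h, tested at 20 uM; on this read-out lower numbers stand for a weaker effect and higher numbers for a stronger effect at the one concentration tested. In this assay compound 1 gives 19.7%. The change from compound 1 to compound 2 is chloro in place of methyl on an aromatic carbon. In this assay compound 2 gives 14.3%. The step is a number 5.4 percentage points lower from compound 1 to compound 2 (within the scatter), so the two values cannot be told apart here. Compound 3 carries a different quaternary end group on the chain and in this assay is reported as "not active" (no number reported), with no number attached. How the core of compound 3 differs from that of compound 1 is not broken down here.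

Compound 4 `CN1CC[N+](C)(CCCCCCCOc2ccc(-n3cc(C(=O)Nc4cc(F)cc(F)c4)c(=O)c4ccc(N(C)C)nc43)c(Cl)c2)CC1` has not yet been measured. It differs from compound 3 by chloro in place of methyl on an aromatic carbon. This is the same change as that from compound 1 to compound 2, and the words describing its place are the same in both cases; among the compounds shown it occurs twice in all.

What to expect for compound 4 rests on two things: the change made from compound 1 to compound 2 was a number 5.4 percentage points lower from compound 1 to compound 2 (within the scatter), so it moved the read-out very little, and the parent compound 3 gave "not active" (no number reported) with no number. On that basis the step from compound 3 to compound 4 is expected to be small as well, and compound 4 is expected to come out weak in this assay, quite possibly again without a reported number. The estimate for compound 4 in this assay is 8%, with a range of 0% to 20%.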

Compound 4, a percentage reported as inhibition, at one concentration (the size of the read-out at that concentration, not a potency): "not active" (no number reported)
For compound 4 the study gives words and no number, so the estimate cannot be set against anything.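

In this assay compound 3 gives "not active" (no number reported) and compound 4 gives "not active" (no number reported), so no step can be read between these two compounds. The compounds shown leave open whether chloro in place of methyl changes the read-out at all when the end group of compound 3 is present. Nothing shown bears on the reason for these two results.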